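The source may hold more compounds than are shown below. What is called first, only, known or untested is meant among the compounds shown, and "the series" means these compounds.

Among the compounds with values here, compound 3 `COc1ccccc1OCC1SCCN1C(C)=O` gives 46 mg/kg in a functional assay on the whole organism for inhibition, with Cavia porcellus as the target (a lower number here means that less compound is needed, a higher number that more compound is needed for the effect), the second highest of the three numbers so far. Compound 2 `COC(=O)c1ccc(OCC2SCCN2C(=O)Cn2ccnc2)cc1` gives 62 mg/kg, which lies within the scatter of compound 3; compound 1 `CCOC(=O)CC(=O)N1CCSC1COc1ccccc1OC` gives 21 mg/kg, the lowest of the set. Within the data shown here, the only step between two measured compounds that differ in one place is a 2.2-fold higher number from compound 1 to compound 3 (0.34 log units; beyond the scatter), so removing the ethoxycarbonyl group from the saturated chain carbon bound to the carbonyl carbon raised the number modestly.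

Compound 4 `CCOC(=O)CCC(=O)N1CCSC1COc1ccccc1OC` differs from compound 3 by (ethoxycarbonyl)methyl in place of hydrogen on a saturated chain carbon bound to a carbonyl carbon. This restores an ester-bearing chain at the same place as in compound 1, one carbon longer. Among the measured compounds shown here, the step from compound 1 to compound 3 bears on it directly and read as a modest change; the extra chain carbon has no precedent, so its effect is unknown. The expectation is a modest lowering of the number, roughly reversing that step, a 1.8-fold lower number from compound 3 to compound 4 (0.26 log units; within the scatter), with the chance that the change stays within the scatter. Compound 4 is estimated at 25 mg/kg in this assay, with a range from 12 mg/kg to 50 mg/kg.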

Compound 4, dose for half-maximal effect: 24 mg/kg
Estimate against measurement, compound 4: 1.0-fold (0.02 log units) above, and the stated range covers the measured number.
By their numbers in this assay, from the lowest: compounds 1, 4, 3 and 2 (each within the scatter of the next, the first and the last beyond it).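

In this assay the two ester-bearing groups at this position cannot be told apart: (ethoxycarbonyl)methyl in place of ethoxycarbonyl on the saturated chain carbon bound to a carbonyl carbon gives a step within the scatter (a 1.1-fold higher number from compound 1 to compound 4 (0.06 log units; within the scatter)). Against hydrogen, (ethoxycarbonyl)methyl also stays within the scatter (a 1.9-fold lower number from compound 3 to compound 4 (0.28 log units; within the scatter)), whereas the step between ethoxycarbonyl and hydrogen lies beyond it (a 2.2-fold higher number from compound 1 to compound 3 (0.34 log units; beyond the scatter)), so a difference from hydrogen is firm only for compound 1. No measured evidence accounts for any of these steps.

Going by these compounds, whether the ester matters at this position, or only the presence of a chain, stays open. A carboxylic acid, an amine or a plain alkyl chain here would separate the two, and a longer chain would test how far the position stays flat.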